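The source may hold more compounds than are shown below. What is called first, only, known or untested is meant among the compounds shown, and "the series" means these compounds.

Series notes. Compound 1 `CC1=C(C(=O)OC2CCC2)C(c2ccco2)NC(=O)N1` serves as the reference of the set; in an assay on membranes from HEK293 cells for displacement of a labelled ligand from adenosine receptor A2b (Homo sapiens), read by scintillation counting, with a stated time of 30 min (a higher number here means a weaker inhibitor, a lower number a stronger inhibitor), compound 1 gives 95.1 nM. Compound 2 `CC1=C(C(=O)OCC2CC2)C(c2ccco2)NC(=O)N1` carries the change (cyclopropylmethyl in place of cyclobutyl on an oxygen next to a carbonyl group), and in this assay compound 2 gives 138 nM, the step being a 1.5-fold higher number from compound 1 to compound 2 (0.16 log units; within the scatter). Compound 3 `CC1=C(C(=O)OC2CCC2)C(c2cccs2)NC(=O)N1` differs from compound 1 in its core by thiophen-2-yl in place of furan-2-yl on a saturated ring carbon; in this assay compound 3 gives 1090 nM, and the step is an 11-fold higher number from compound 1 to compound 3 (1.06 log units; beyond the scatter), the widest gap among the three measured compounds. Compound 4 `CC1=C(C(=O)OCC2CC2)C(c2cccs2)NC(=O)N1` has not yet been measured. It stands to compound 3 as compound 2 stands to compound 1: the change is cyclopropylmethyl in place of cyclobutyl on an oxygen next to a carbonyl group, made at the same place in both pairs, so it is the same change carried out on the core of compound 3 instead of the core of compound 1. The step from compound 3 to compound 4 is expected to be about a 1.4-fold higher number from compound 3 to compound 4 (0.14 log units; within the scatter), set beside the measured 1.5-fold higher number from compound 1 to compound 2 (0.16 log units; within the scatter), which lay within the scatter, and nothing in the set shows the two cores answering this change differently. Compound 4 is therefore estimated at 1500 nM in this assay, with a range from 700 nM to 3500 nM.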

Compound 4, inhibition constant: 1570 nM
Compound 4: the middle estimate sits 1.0-fold (0.02 log units) below what was measured; measured number inside the range.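

In this assay, cyclopropylmethyl in place of cyclobutyl carries over from the core of compound 1 to the core of compound 3, with a 1.4-fold higher number from compound 3 to compound 4 (0.16 log units; within the scatter) staying within the scatter as the earlier step did: the same change on two cores in this assay, a 1.5-fold higher number (0.16 log units; within the scatter) from compound 1 to compound 2 and a 1.4-fold higher number (0.16 log units; within the scatter) from compound 3 to compound 4, 1.0-fold (0.00 log units) apart, within the scatter of two such steps

The large step for thiophen-2-yl in place of furan-2-yl also recurs with cyclopropylmethyl on the oxygen, as an 11-fold higher number from compound 2 to compound 4 (1.06 log units; beyond the scatter): the same change on two cores in this assay, an 11-fold higher number (1.06 log units; beyond the scatter) from compound 1 to compound 3 and an 11-fold higher number (1.06 log units; beyond the scatter) from compound 2 to compound 4, 1.0-fold (0.00 log units) apart, within the scatter of two such steps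

The two changes therefore behave independently across compound 1, compound 2, compound 3 and compound 4, but this single set of four shows neither that this holds for other groups nor why the thiophen-2-yl compounds give the higher numbers, and a step within the scatter is only a weak test of transfer.

The compounds shown leave open how a longer chain such as n-pentyl, or a basic amine, on the oxygen would respond to the same change of ring. They also leave open whether a phenyl group on the saturated ring carbon would follow the step seen for thiophen-2-yl.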